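A few compounds are considered here, and "the series" means these few. Any claim that something is new, unique, unknown or untested is made for them only; others in the source may bear on it.

Compound 1 `O=C([C@@H]1C[C@H](N2CCN(c3ccccn3)CC2)CN1)N1CCSC1`: 3.5 nM
Compound 2 `O=C([C@@H]1C[C@H](N2CCN(c3cccc(Cl)c3)CC2)CN1)N1CCSC1`: 7.2 nM

For the measured compounds named here, in an assay on a cell-free system (plasma) for inhibition of Dipeptidyl peptidase 4 (Rattus norvegicus), read by fluorescence (a higher number here means a weaker inhibitor, a lower number a stronger inhibitor), compound 2 gives the higher of the two numbers, with compound 1 the only neighbour, a 2.1-fold higher number from compound 1 to compound 2 (0.31 log units; beyond the scatter). Compound 3 `O=C([C@@H]1C[C@H](N2CCN(c3ccncc3)CC2)CN1)N1CCSC1` carries pyridin-4-yl in place of 3-chlorophenyl on an amine nitrogen in a ring. Going by the values given here, only that one measured step bears on the change: exchanging a pyridyl for 3-chlorophenyl raised the number modestly, so returning to a pyridyl, though a different isomer, is expected to lower it by a similar modest amount, a 1.6-fold lower number from compound 2 to compound 3 (0.20 log units; within the scatter). Compound 3 is therefore estimated at 4.5 nM in this assay, within a range of 1.5 nM to 14 nM.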

Compound 3, half-maximal inhibitory concentration: 3.9 nM
Compound 3: middle estimate off by 1.2-fold (0.06 log units), on the high side; the range from low to high includes it.
By their numbers in this assay, from the lowest: compounds 1, 3 and 2 (each within the scatter of the next, the first and the last beyond it).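

In this assay, moving the ring nitrogen from pyridin-2-yl to pyridin-4-yl gives a 1.1-fold higher number from compound 1 to compound 3 (0.05 log units; within the scatter), so the two pyridyl isomers cannot be told apart at this position. The other step, a 1.8-fold lower number from compound 2 to compound 3 (0.27 log units; within the scatter), also stays within the scatter, so pyridin-4-yl cannot be separated from 3-chlorophenyl either. Only compound 1 and compound 2 remain apart, and compound 3 fits within the scatter of both.

Nothing at hand gives a reason for these numbers. On these data alone, how a saturated cyclohexyl ring or a carboxylic acid on the aromatic ring would fare on this amine nitrogen stays open.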